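Phenylethynyl in place of butyl on the chain

The compounds below may be only part of what the source reports. "The series", "measured", "known", "first", "only" and "open" are said of these compounds alone.

In a functional assay on cells (T-cell line, Homo sapiens) for inhibition (a lower number here means a stronger inhibitor, a higher number a weaker inhibitor), compound 1 (`Cc1ccc(CCCN2CCC(COC(c3ccccc3)c3ccccc3)CC2)cc1`) gives 200 nM and compound 3 (`CCCCCN1CCC(COC(c2ccccc2)c2ccccc2)CC1`) gives 10800 nM, the higher of the two exact numbers. Compound 2 (`CCN1CCC(COC(c2ccccc2)c2ccccc2)CC1`) gives > 20000 nM, which is a limit. Compound 4 (`C(#Cc1ccccc1)CN1CCC(COC(c2ccccc2)c2ccccc2)CC1`) carries 2-phenylethynyl in place of butyl on a saturated chain carbon bound to an amine nitrogen in a ring. The closest guide is a 54-fold higher number from compound 1 to compound 3 (1.73 log units; beyond the scatter), with ethyl in place of 4-methylphenyl. The step of an at least 100-fold higher number from compound 1 to compound 2 (2.00 log units; beyond the scatter) points the same way, while an at least 1.8-fold lower number from compound 2 to compound 3 (0.26 log units; that floor lies within the scatter) has a floor within the scatter. Among the measured compounds shown here, no measured compound carries a triple bond, so only part of that gap is expected to return, as a 9.0-fold lower number from compound 3 to compound 4 (0.95 log units; beyond the scatter). The estimate for compound 4 is 1200 nM, with an expected range of 250 nM to 6000 nM.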

Compound 4, half-maximal inhibitory concentration: > 20000 nM
Compound 4 was reported as a limit; the forecaster's own chance of this, stated with the estimate: 5%; middle value at least 16-fold (1.22 log units) away from the limit.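

In this assay, 2-phenylethynyl in place of butyl gives an at least 1.8-fold higher number from compound 3 to compound 4 (0.26 log units; that floor lies within the scatter), so no gain from the added aromatic ring can be read at this position. Against the 4-methylphenyl-ended chain, the same group gives an at least 100-fold higher number from compound 1 to compound 4 (2.00 log units; beyond the scatter), so a chain-end aromatic ring alone does not restore the potency of compound 1. The step from compound 2 to compound 4 cannot be read because both values are limits: the limit of > 20000 nM in this assay, at which 2 of the 4 values shown sit.

Open, on these data alone, is whether a saturated 3-phenylpropyl chain lacking the methyl group, or a 3-(pyridyl)propyl chain, holds the potency of compound 1. As far as these compounds go, how far compound 4 lies beyond its limit also stays open.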